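This account rests on a few compounds, and the source may have more. Where it says the series, first, only, none or still open, it means among the compounds named here.

Compound 1 `O=C1c2ccc(OCc3cccc(-c4ccc(Cl)cc4F)c3)cc2CN1C1CCCC1`: "not determined" (no result reported)
Compound 2 `COc1ccc(-c2cccc(COc3ccc4c(c3)CN(C3CCCC3)C4=O)c2)cc1C(=O)O`: 84%

The measurement followed here is an ADME assay on microsomes from liver (Rattus norvegicus) for metabolic stability, read by LC-MS, with a stated time of 1 h, at 37 degrees C, tested at 4 uM; on this read-out higher numbers stand for a more stable compound and lower numbers for a less stable compound. In this assay, compound 2 gives 84%. Going by the values given here, this is the only number available, so compound 2 cannot yet be ranked against any other compound. Compound 1 offers no comparison, as it has no reported result.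

The next compound to be tested is compound 3 `Cc1ccc(C(=O)O)cc1-c1cccc(COc2ccc3c(c2)CN(C2CCCC2)C3=O)c1`. It keeps the shared core and differs from compound 2 in one place: 5-carboxy-2-methylphenyl in place of 3-carboxy-4-methoxyphenyl on an aromatic carbon. In words, 5-carboxy-2-methylphenyl stands in place of 3-carboxy-4-methoxyphenyl on an aromatic carbon. Both groups carry a carboxy group, and the difference lies in what else is attached to the aromatic ring.

Among the compounds with values here, no measured pair shows what such a swap does, so the expectation rests on a single anchor, compound 2 at 84%. With no evidence for a direction, no change beyond the usual scatter is expected. The estimated shift is small, a number 2 percentage points lower from compound 2 to compound 3 (within the scatter). For compound 3 the expected value is 82%, with an estimated range of 62% to 96%.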

Compound 3, percent of the compound remaining: 2%
Compound 3: middle estimate off by 80 percentage points, on the high side; the whole stated range lies above it.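

In this assay, putting 5-carboxy-2-methylphenyl in place of 3-carboxy-4-methoxyphenyl on an aromatic carbon gives a number 82 percentage points lower from compound 2 to compound 3 (beyond the scatter). This position on the shared core therefore does not tolerate every change to the ring it carries: both groups have a carboxy group and differ only in what else is attached, yet the result in this assay is very different, so the presence of a carboxy group on this ring is not enough to preserve the read-out. Nothing available here explains the drop.

The swap changes more than one feature at once: a methoxy group leaves, a methyl group enters, and the substituents are arranged differently on the ring, so these compounds cannot show which of these changes matters, or whether it takes them together. Going by these compounds, it also remains open how this position would respond to a ring with a different substituent in place of the carboxy group, such as an amine or a nitrile, or to an ethyl group in place of the methyl group.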